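A few compounds are considered here, and "the series" means these few. Any claim that something is new, unique, unknown or untested is made for them only; others in the source may bear on it.

The measured compounds:
compound 1, `NC(=O)Cn1c(-c2ccc(Br)cc2)nc2cccnc21`, 17.8 mg/kg;
compound 2, `CN(C)C(=O)Cn1c(-c2ccc(Br)cc2)nc2cccnc21`, 7 mg/kg;
compound 3, `NC(=O)Cn1c(-c2ccc(Cl)cc2)nc2ccc[n+]([O-])c21`, 52.1 mg/kg.

All three were tested in a functional assay on the whole organism with Mus musculus as the target; on this read-out lower numbers stand for an effect already at smaller amounts and higher numbers for an effect only at larger amounts of compound. Compound 1 and compound 2 share one core and differ in a single place: dimethylamino in place of amino on a carbonyl carbon. That change gave a 2.5-fold lower number from compound 1 to compound 2 (0.41 log units; beyond the scatter). Compound 3 is built on a different core, and the difference between the two cores is not broken down here. In this assay compound 3 gives 52.1 mg/kg, the highest of the three numbers.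

Compound 4, `CN(C)C(=O)Cn1c(-c2ccc(Cl)cc2)nc2ccc[n+]([O-])c21`, has not yet been measured. It stands to compound 3 as compound 2 stands to compound 1: dimethylamino in place of amino on a carbonyl carbon. The surroundings of the change are the same in both pairs, so this is the same change, occurring for the second time among the compounds shown. Because the earlier pair gave a 2.5-fold lower number from compound 1 to compound 2 (0.41 log units; beyond the scatter), compound 4 is expected to show a 2.4-fold lower number from compound 3 to compound 4 (0.37 log units; beyond the scatter). This expectation rests on a single earlier pair on a different core, so it is held loosely. For compound 4 in this assay the estimate is 22 mg/kg, with a likely range from 10 mg/kg to 50 mg/kg.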

Compound 4, dose for half-maximal effect: 20 mg/kg
Beside the measured number, compound 4's estimate is 1.1-fold (0.04 log units) above it; the measured number falls inside the stated range.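

In this assay, dimethylamino in place of amino on a carbonyl carbon gave a 2.6-fold lower number from compound 3 to compound 4 (0.42 log units; beyond the scatter), and the size of the step held from one core to the other: the same change on two cores in this assay, a 2.5-fold lower number (0.41 log units; beyond the scatter) from compound 1 to compound 2 and a 2.6-fold lower number (0.42 log units; beyond the scatter) from compound 3 to compound 4, 1.0-fold (0.01 log units) apart, within the scatter of two such steps. Among the compounds shown, the change therefore carries over between these two cores, and on each the dimethylamino compound gives the lower number. For the compounds shown here, this rests on only two pairs in a single read-out, so it does not show that the step would keep its size on a further core, nor does it explain why the number falls.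

The compounds shown leave open whether methylamino or diethylamino on the same carbonyl carbon, or a carboxylic acid in place of the amide, would move the number in the same direction and by a similar amount. They also leave open how much the difference between the two cores contributes to the numbers, since that difference is not broken down into single changes.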